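Removing the chloro group: compound 1 to compound 4

The source may hold more compounds than are shown below. What is called first, only, known or untested is meant among the compounds shown, and "the series" means these compounds.

Measured compounds:
compound 1, `O=C1CCCC2=C1C(c1ccc(Cl)cc1)C=C(c1ccccc1)N2`: 8.21%
compound 2, `CC1(C)CC(=O)C2=C(C1)NC(C(=O)O)=CC2c1ccccc1`: 17.1%
compound 3, `CC1(C)CC(=O)C2=C(C1)NC(c1ccccc1)=CC2c1ccc(Cl)cc1`: 7.16%

Of the compounds shown here, three sharing a dihydropyridinone core have been tested in an assay on isolated protein for inhibition of glucose-6-phosphatase catalytic subunit 1 (Homo sapiens), read by inositol phosphate accumulation, with a stated time of 30 min, tested at 100 uM; on this read-out higher numbers stand for more inhibition at the one concentration tested (going by the name of the read-out) and lower numbers for less inhibition. Compound 1, `O=C1CCCC2=C1C(c1ccc(Cl)cc1)C=C(c1ccccc1)N2`, gives 8.21% in this assay. Compound 2, `CC1(C)CC(=O)C2=C(C1)NC(C(=O)O)=CC2c1ccccc1`, gives 17.1%, and compound 3, `CC1(C)CC(=O)C2=C(C1)NC(c1ccccc1)=CC2c1ccc(Cl)cc1`, gives 7.16%. On the numbers shown, compound 1 stands second of the three; the value of compound 3 lies within the usual scatter of it, and so does the value of compound 2, which is the furthest of the three from compound 1. Nothing among these three, then, separates them beyond the scatter of repeated measurement.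

The next compound, compound 4, `O=C1CCCC2=C1C(c1ccccc1)C=C(c1ccccc1)N2`, differs from compound 1 in one place: hydrogen in place of chloro on an aromatic carbon. Among the compounds with values here, since no step between two measured compounds can be drawn from the numbers at hand, and since all three measured values sit close together, an expectation for compound 4 can only be anchored on compound 1 itself. The step from compound 1 to compound 4 is expected to be a number 0.8 percentage points higher from compound 1 to compound 4 (within the scatter), that is, none beyond the scatter. Compound 4 is therefore estimated at 9% in this assay, with a range from 0% to 19%.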

Compound 4, a percentage reported as inhibition, at one concentration (the size of the read-out at that concentration, not a potency): "not active" (no number reported)
No number was reported for compound 4, so the estimate cannot be set against anything.
By their numbers in this assay, from the lowest: compounds 3, 1 and 2 (each within the scatter of the next).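

Within the data shown here, compound 4 is recorded as "not active" in this assay, with no number reported, so no step from compound 1 to compound 4 can be read. The compounds shown leave open how far the change from 4-chlorophenyl to phenyl shifts inhibition, if at all. Nothing else shown bears on this result.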